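Oxime ether series: aryl swap on the fused core

A few compounds are considered here, and "the series" means these few. Any claim that something is new, unique, unknown or untested is made for them only; others in the source may bear on it.

Measured so far:
compound 1, `C(=N/OCc1ccccc1)\c1c(-c2ccc3ccccc3c2)nc2occn12`: 840 nM
compound 2, `Clc1ccc(CO/N=C/c2c(-c3ccc(-c4ccccc4)cc3)nc3sccn23)cc1Cl`: "not active" (no number reported)
compound 3, `Clc1ccc(CO/N=C/c2c(-c3cccc4ccccc34)nc3sccn23)cc1Cl`: 940 nM

In an assay on HepG2 cells for agonist activity at nuclear receptor subfamily 1 group I member 3 (Homo sapiens), read by a luciferase reporter, with a stated time of 23 h (a lower number here means that less compound is needed, a higher number that more compound is needed for the effect), compound 3 gives 940 nM, the higher of the two numbers in hand. Its nearest neighbour on the numbers is compound 1, and the gap between the two lies within the scatter, so nothing separates them. Compound 2 returns no number at all in this assay and is reported only as inactive. Going by the values given here, no two measured compounds differ in a single place, so no measured step is available for the change considered here.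

Compound 4, `Fc1ccc(-c2nc3sccn3c2/C=N/OCc2ccc(Cl)c(Cl)c2)cc1`, is the next entry to be measured in this assay. It differs from compound 3 as follows: 4-fluorophenyl in place of naphthalen-1-yl on an aromatic carbon. Among the compounds with values here, the only measured compound that carries a single six-membered aromatic ring on this position, compound 2, gave no number, while both compounds with a naphthyl group gave values near one another. On that basis a step in this assay toward a higher number, beyond the scatter, is expected from compound 3 to compound 4, as a 3.7-fold higher number from compound 3 to compound 4 (0.57 log units; beyond the scatter).

Compound 4 is therefore estimated at 3500 nM in this assay, with a plausible range of 900 nM to 15000 nM, and a real chance that only an inactive call is returned.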

Compound 4, half-maximal effective concentration: 670 nM
The estimate for compound 4 lay 5.2-fold (0.72 log units) above the measured number; measured number below the stated range.
By their numbers in this assay, from the lowest: compounds 4, 1 and 3 (each within the scatter of the next).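

In this assay the change gives a 1.4-fold lower number from compound 3 to compound 4 (0.15 log units; within the scatter), so 4-fluorophenyl and naphthalen-1-yl are not told apart on this aromatic carbon, and the second six-membered aromatic ring of naphthalen-1-yl is not needed for a number to be returned. Compound 2 differs from compound 4 only in the group on this carbon, yet its biphenyl group is reported as not active, so the absence of a number there cannot be read as a general failure of groups other than naphthyl, and this position does not accept every aryl group alike. Nothing measured here explains why these groups give similar or different outcomes, and no supporting evidence bears on the result.

The series shown holds no plain phenyl on this carbon, so the part played by the fluorine in compound 4 remains unresolved. On these data alone, it is also open whether a pyridine ring, a 4-methoxyphenyl or a 4-aminophenyl group would still return a number in this assay, and how far larger groups can go before the outcome seen with compound 2 appears.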